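The source may report more compounds than this note shows. Statements on the series, on what has been measured and on what is new or still open speak of the compounds shown alone.

Compound 1: `CN1CCN(c2nc(-c3cccc(O)c3)nc3c2ncn3C)CC1` gives 63.8% in an assay on cells for displacement of a labelled ligand from adenosine receptor A3 (Homo sapiens), read by scintillation counting and radioligand binding, with a stated time of 180 min, tested at 10 uM; on this read-out higher numbers stand for more inhibition at the one concentration tested (going by the name of the read-out) and lower numbers for less inhibition.
Compound 2: `CN1CCN(c2nc(-c3ccc(Cl)c(Cl)c3)nc3[nH]cnc23)CC1` gives > 80% in this assay, which is a limit of the assay and not a number.
Compound 3: `CN1CCN(c2nc(-c3ccc(Cl)c(C(F)(F)F)c3)nc3[nH]cnc23)CC1` gives > 80% in this assay, again a limit of the assay.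

Among these three, compound 1 is the only one with a read number; the other two sit at the limit described by the limit of > 80% in this assay, at which 2 of the 3 values shown sit. Within the data shown here, the single step between measured compounds, a step that the two limits leave unreadable from compound 2 to compound 3, runs from one limit to another and so has no readable size. Nothing measured therefore speaks to how the core responds to a change on the attached phenyl ring.

Compound 4, `CN1CCN(c2nc(-c3ccccc3O)nc3c2ncn3C)CC1`, is still to be measured. Its difference from compound 1 is 2-hydroxyphenyl in place of 3-hydroxyphenyl on an aromatic carbon. Among the measured compounds shown here, no measured step bears on this change, so the expected step from compound 1 to compound 4 is a number 1.8 percentage points lower from compound 1 to compound 4 (within the scatter), none beyond the scatter. Compound 4 is estimated at 62% in this assay, within a range from 40% to 82%.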

Compound 4, a percentage reported as inhibition, at one concentration (the size of the read-out at that concentration, not a potency): 15.3%
The estimate for compound 4 lay 46.7 percentage points above the measured number; measured number outside the range, below it.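

In this assay the exchange of 3-hydroxyphenyl for 2-hydroxyphenyl gives a number 48.5 percentage points lower from compound 1 to compound 4 (beyond the scatter) and is the only readable step among the compounds shown. The two compounds have the same atoms joined differently, so where the hydroxyl sits on the phenyl ring, itself attached between two ring nitrogen atoms of the shared core, clearly matters in this read-out, which the unreadable step between the two earlier limits could not show. No measurement shown gives a reason for this drop.

The compounds shown leave open whether an amine, a methoxy group or a carboxylic acid in place of the hydroxyl would hold the reading of compound 1. They also leave open whether the same change would have a similar effect on the core of compound 2.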